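Amide substituent change from compound 2 to compound 3

The source may report more compounds than this note shows. Statements on the series, on what has been measured and on what is new or still open speak of the compounds shown alone.

Measured in a physicochemical assay for solubility, read by spectrophotometry, measured as kinetic solubility, at pH 8, tested at 500 uM; on this read-out higher numbers stand for higher solubility and lower numbers for lower solubility:
compound 1 `Cn1cc(NC(=O)c2ccncc2Nc2cc(-c3ccc4ccn(C)c4c3)c3nccnc3c2)cn1`: 2 ug/mL
compound 2 `Cn1ccc2ccc(-c3cc(Nc4cnccc4C(=O)NC4CCNC(=O)C4)cc4nccnc34)cc21`: 242 ug/mL

Of the two measured compounds, compound 2 carries the higher number, at 242 ug/mL. The next case is compound 3 `CC(=O)N1CCOC(CNC(=O)c2ccncc2Nc2cc(-c3ccc4ccn(C)c4c3)c3nccnc3c2)C1`, which differs from it as follows: (4-acetylmorpholin-2-yl)methyl in place of 2-oxopiperidin-4-yl on an amide-type nitrogen. Among the compounds with values here, one measured step bears on this change, at the same amide-type nitrogen: a 120-fold higher number from compound 1 to compound 2 (2.08 log units; beyond the scatter), a large step. Compound 3 keeps a six-membered non-aromatic ring in that substituent, as compound 2 does, so a fall of that size is not expected in this assay. That single step says nothing direct about the (4-acetylmorpholin-2-yl)methyl group, so the range stays wide, with a lean to lower numbers. The expected change is a 1.5-fold lower number from compound 2 to compound 3 (0.18 log units; within the scatter), with no step beyond the scatter expected. For compound 3 the estimate is 160 ug/mL, with an expected range of 50 ug/mL to 280 ug/mL.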

Compound 3, solubility: 268 ug/mL
For compound 3 the middle estimate is 1.7-fold (0.22 log units) below the measured one; low and high end bracket the measured number.
By their numbers in this assay, from the lowest: compound 1; then compounds 2 and 3 (each within the scatter of the next).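

At the amide-type nitrogen, this assay gives a 1.1-fold higher number from compound 2 to compound 3 (0.04 log units; within the scatter) and a 130-fold higher number from compound 1 to compound 3 (2.13 log units; beyond the scatter), the latter a large step. The large step from 1-methyl-1H-pyrazol-4-yl therefore no longer rests on 2-oxopiperidin-4-yl alone, and in this pair the hydrogen-bond donor of that group, 1 against 0 in (4-acetylmorpholin-2-yl)methyl, is not needed to keep the number high. No measurement on hand gives a reason for either step.

Open, going by these compounds, is whether an open-chain substituent at this nitrogen, such as a longer alkyl chain or a chain ending in an amine or a carboxylic acid, stays near compound 3 or falls towards compound 1. Also open, on these data alone, is whether the six-membered non-aromatic ring itself matters, or only the departure of 1-methyl-1H-pyrazol-4-yl.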